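The source may report more compounds than this note shows. Statements on the series, on what has been measured and on what is new or still open speak of the compounds shown alone.

Working notes on the series.

Of the compounds shown here, three with the shared core have been measured in a functional assay on RPMI-8226 cells (Homo sapiens) for inhibition, read by sulforhodamine B assay, with a stated time of 48 h; a lower number here means a stronger inhibitor, a higher number a weaker inhibitor. Compound 1 `COc1cc(-c2nn(-c3cccc(NC(=O)Nc4ccc(Cl)c(Cl)c4)c3)cc2-c2ccncc2)ccc1Cl` gives 390 nM. Compound 2 `COc1cc(-c2nn(-c3cccc(NC(=O)Nc4cccc(C(F)(F)F)c4)c3)cc2-c2ccncc2)ccc1Cl` gives 340 nM; the step of a 1.1-fold lower number from compound 1 to compound 2 (0.06 log units; within the scatter) lies within the scatter. Compound 3 `COc1cc(-c2nn(-c3cccc(NC(=O)Nc4ccc(Cl)c(C(F)(F)F)c4)c3)cc2-c2ccncc2)ccc1Cl` gives 870 nM, the highest of the three numbers: a 2.2-fold higher number from compound 1 to compound 3 (0.35 log units; beyond the scatter) and a 2.6-fold higher number from compound 2 to compound 3 (0.41 log units; beyond the scatter) are both beyond the scatter, so compound 3 is the weakest inhibitor measured so far.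

Compound 4 `COc1cc(-c2nn(-c3cccc(NC(=O)c4ccccc4)c3)cc2-c2ccncc2)ccc1Cl` is not yet measured. It differs from compound 3 by phenyl in place of (4-chloro-3-(trifluoromethyl)phenyl)amino on a carbonyl carbon. The measured steps only vary the groups on the aromatic ring that sits beyond the amino link; none removes that link itself, so neither a 2.2-fold higher number from compound 1 to compound 3 (0.35 log units; beyond the scatter) nor a 2.6-fold higher number from compound 2 to compound 3 (0.41 log units; beyond the scatter) bears directly on this change. The replacement is larger than any step seen here, and the direction cannot be read from the measured compounds. As a working expectation, compound 4 is estimated at 2000 nM in this assay, with a range of 400 nM to 10000 nM, meaning an expected step of a 2.3-fold higher number from compound 3 to compound 4 (0.36 log units; beyond the scatter).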

Compound 4, half-maximal inhibitory concentration: 850 nM
Beside the measured number, compound 4's estimate is 2.4-fold (0.37 log units) above it; the range from low to high includes it.
By their numbers in this assay, from the lowest: compounds 2 and 1 (each within the scatter of the next); then compounds 4 and 3 (each within the scatter of the next).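

Losing the amino link together with the substituted ring is tolerated when read from compound 3: in this assay, a 1.0-fold lower number from compound 3 to compound 4 (0.01 log units; within the scatter) lies within the scatter, so the two numbers cannot be told apart. The same kind of replacement reads differently from the other two ureas, with a 2.5-fold higher number from compound 2 to compound 4 (0.40 log units; beyond the scatter) and a 2.2-fold higher number from compound 1 to compound 4 (0.34 log units; beyond the scatter) both beyond the scatter and modest, so the outcome of this change depends on which substituted ring leaves. The data here give no reason for this difference.

The compounds shown do not separate the contribution of the amino link from that of the chloro and trifluoromethyl groups; a plain phenylamino group on the carbonyl carbon would do so. On these data alone, whether the phenyl itself matters remains open, and a methyl group or a morpholine in its place would test that.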